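A few compounds are considered here, and "the series" means these few. Any claim that something is new, unique, unknown or untested is made for them only; others in the source may bear on it.

Of the compounds shown here, three with a shared core have been measured in a functional assay on HeLa cells (Homo sapiens) for cytotoxicity, read by MTT assay, with a stated time of 48 h; on this read-out higher numbers stand for weaker inhibition and lower numbers for stronger inhibition. Compound 1 (`O=C(O)CN1C(=O)/C(=C/c2nc3ccccc3n2Cc2ccc(Br)cc2)SC1=S`) gives 12900 nM, compound 2 (`O=C(O)CN1C(=O)/C(=C/c2nc3ccccc3n2Cc2ccc([N+](=O)[O-])cc2)SC1=S`) gives 18600 nM, and compound 3 (`Cc1ccc(Cn2c(/C=C3\SC(=S)N(CC(=O)O)C3=O)nc3ccccc32)cc1`) gives 1280 nM, the lowest of the three. The next structure, compound 4 (`O=C(O)CN1C(=O)/C(=C/c2nc3ccccc3n2Cc2ccc(C(F)(F)F)cc2)SC1=S`), differs from compound 3 in one group: trifluoromethyl in place of methyl on an aromatic carbon. Put simply, trifluoromethyl stands in place of methyl on an aromatic carbon.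

Among the compounds with values here, two measured steps bear on this change, and both end at the methyl compound: a 10-fold lower number from compound 1 to compound 3 (1.00 log units; beyond the scatter) and a 15-fold lower number from compound 2 to compound 3 (1.16 log units; beyond the scatter). The step between bromo and nitro is a 1.4-fold higher number from compound 1 to compound 2 (0.16 log units; within the scatter), so those two cannot be told apart. Within the data shown here, no measured compound carries trifluoromethyl, so the guide is limited: the two compounds without methyl both sit well above compound 3. A rise of similar or somewhat smaller size therefore seems likely. In this assay the expected step is a 7.0-fold higher number from compound 3 to compound 4 (0.85 log units; beyond the scatter), an estimate with wide uncertainty. The estimated value for compound 4 is 9000 nM, with an expected range from 2500 nM to 25000 nM.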

Compound 4, half-maximal inhibitory concentration: 21400 nM
For compound 4 the middle estimate is 2.4-fold (0.38 log units) below the measured one; the range from low to high includes it.
By their numbers in this assay, from the lowest: compound 3; then compounds 1, 2 and 4 (each within the scatter of the next).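

Trifluoromethyl at this place on the ring brings a 17-fold higher number from compound 3 to compound 4 (1.22 log units; beyond the scatter), so a third group without methyl's low number has now joined the series. Compound 4 cannot be told apart from the other two compounds in this group, since a 1.2-fold higher number from compound 2 to compound 4 (0.06 log units; within the scatter) and a 1.7-fold higher number from compound 1 to compound 4 (0.22 log units; within the scatter) both lie within the scatter. Bromo, nitro and trifluoromethyl therefore form one cluster of high numbers, and among these four compounds only the methyl of compound 3, at 1280 nM, stands clearly apart.

Nothing in the available data explains why methyl differs from the other three groups. The compounds shown leave open whether an ethyl group, a methoxy group or an amine at this same place would share the low number of compound 3 or fall into the cluster.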